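Sulfoxide Analogue of a Catechol Vinyl Sulfone Series

The compounds below may be only part of what the source reports. "The series", "measured", "known", "first", "only" and "open" are said of these compounds alone.

Measured compounds:
Compound 1, `O=S(=O)(/C=C/c1ccc(O)c(O)c1)Cc1ccc(Cl)cc1`: 11700 nM
Compound 2, `CC(C)(C)c1ccc(CS(=O)(=O)/C=C/c2ccc(O)c(O)c2)cc1`: 12600 nM
Compound 3, `[O-][S+](/C=C/c1ccc(O)c(O)c1)Cc1ccc(Cl)cc1`: 14000 nM

All three were examined in a functional assay on BV-2 cells (Mus musculus) for inhibition, read by Griess assay, with stated times of 3 h and 24 h; on this read-out higher numbers stand for weaker inhibition and lower numbers for stronger inhibition. Compound 1 and compound 2 share one core and differ by tert-butyl in place of chloro on an aromatic carbon. The step of a 1.1-fold higher number from compound 1 to compound 2 (0.03 log units; within the scatter) shows that this change left the result essentially unmoved. Compound 3 carries a different core; the difference between the two cores is not broken down here. Its result in this assay sits close to those of compound 1 and compound 2, with no separation beyond the usual scatter among the three.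

Compound 4, `CC(C)(C)c1ccc(C[S+]([O-])/C=C/c2ccc(O)c(O)c2)cc1`, has not yet been measured. It stands to compound 3 as compound 2 stands to compound 1: the change is tert-butyl in place of chloro on an aromatic carbon, and the place is described in the same words in both cases, so it is the same change. Because the step of a 1.1-fold higher number from compound 1 to compound 2 (0.03 log units; within the scatter) was within the scatter, compound 4 is expected to lie near compound 3, with an expected step of a 1.1-fold higher number from compound 3 to compound 4 (0.03 log units; within the scatter). Compound 4 is accordingly estimated at 15000 nM in this assay, most likely between 8000 nM and 28000 nM.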

Compound 4, half-maximal inhibitory concentration: 9300 nM
The estimate for compound 4 lay 1.6-fold (0.21 log units) above the measured number; measured number inside the range.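

In this assay, tert-butyl in place of chloro on the aromatic carbon again left the result within the usual scatter, with a 1.5-fold lower number from compound 3 to compound 4 (0.18 log units; within the scatter). Set side by side, the steps on the two cores do not separate, so in this small set the change carries over from one core to the other as a swap with no readable effect: the same change on two cores in this assay, a 1.1-fold higher number (0.03 log units; within the scatter) from compound 1 to compound 2 and a 1.5-fold lower number (0.18 log units; within the scatter) from compound 3 to compound 4, 1.6-fold (0.21 log units) apart, within the scatter of two such steps. For the compounds shown here, this shows only that the exchange of these two groups made no clear difference on either core; with one pair per core, it neither places chloro and tert-butyl in any order nor shows that the same would hold on a further core.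

The compounds shown leave open whether other groups in that place, such as an amine, a carboxylic acid or a longer chain, would also stay within the scatter. They also leave open whether such groups would give the same result on both cores or would set the two cores apart.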